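Working notes: aryl change from compound 2 to compound 3

The source may hold more compounds than are shown below. What is called first, only, known or untested is meant among the compounds shown, and "the series" means these compounds.

In a functional assay on A549 cells (Homo sapiens) for cytotoxicity, read by sulforhodamine B assay (a higher number here means a weaker inhibitor, a lower number a stronger inhibitor), compound 1 `Cc1ccc2c(S)nc(-c3ccccc3)cc2c1` gives 8510 nM; 11000 nM (2 entries). For the measured compounds named here, compound 2 `COc1ccc(-c2cc3cc(C)ccc3c(N3CCN(C)CC3)n2)cc1` gives 7410 nM, its only single number there, and one further entry for compound 2 carries no single number. The values of compound 1 and compound 2 lie within the usual scatter of each other. Compound 3 `Cc1ccc2c(N3CCN(C)CC3)nc(-c3ccccc3C)cc2c1` has 2-methylphenyl in place of 4-methoxyphenyl on an aromatic carbon. Going by the values given here, no measured step covers this change. No shift beyond the scatter is expected in this assay, in either direction. The expected step of a 1.1-fold higher number from compound 2 to compound 3 (0.03 log units; within the scatter) is small. Compound 3 is estimated at 8000 nM, with an expected range of 3500 nM to 18000 nM.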

Compound 3, half-maximal inhibitory concentration: 7590 nM
Beside the measured number, compound 3's estimate is 1.1-fold (0.02 log units) above it; measured number inside the range.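

In this assay, for the compounds shown here, the exchange of 4-methoxyphenyl for 2-methylphenyl gives the first measured step at this position: a 1.0-fold higher number from compound 2 to compound 3 (0.01 log units; within the scatter). This aryl change therefore leaves the read-out within the scatter, and the step is no larger than the spread between repeat entries of a single compound: the several entries of compound 1 in this assay, 8510 nM; 11000 nM (2 entries)

Open, as far as these compounds go, is whether this position tolerates an aryl group bearing a carboxylic acid or a primary amine. Also open, from the compounds shown here alone, is how a morpholine would read in place of the 4-methylpiperazin-1-yl group.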